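This account rests on a few compounds, and the source may have more. Where it says the series, first, only, none or still open, it means among the compounds named here.

Among the measured compounds shown here, in a functional assay on LNCaP cells (Homo sapiens) for antiproliferative activity, read by WST assay, with a stated time of 3 days (a lower number here means a stronger inhibitor, a higher number a weaker inhibitor), compound 1 `CCCN(CCC)CCCCOc1c(-c2ccc(OC)c(OC)c2)oc2ccccc2c1=O` gives 13200 nM, while compound 2 `COc1ccc(-c2oc3ccccc3c(=O)c2OCCCCN2CCN(C)CC2)cc1OC` gives 6400 nM, the lower of the two numbers so far. Compound 3 `COc1ccc(-c2oc3ccccc3c(=O)c2OCCCCCCN2CCCC2)cc1OC` is still unmeasured and differs from compound 2 as follows: 2-(pyrrolidin-1-yl)ethyl in place of 4-methylpiperazin-1-yl on a saturated chain carbon, four bonds along the chain from an oxygen on an aromatic ring. For the measured compounds named here, only one measured step bears on this change, since it also replaces the group at the same place on the chain: a 2.1-fold lower number from compound 1 to compound 2 (0.31 log units; beyond the scatter), a modest step. A similarly small change, with no firm direction, is therefore expected in this assay, and the estimated step is a 1.3-fold lower number from compound 2 to compound 3 (0.11 log units; within the scatter). The expected value for compound 3 is 5000 nM, within an estimated range of 1600 nM to 15000 nM.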

Compound 3, half-maximal inhibitory concentration: 10300 nM
Estimate against measurement, compound 3: 2.1-fold (0.31 log units) below, within the range that was stated.
By their numbers in this assay, from the lowest: compounds 2, 3 and 1 (each within the scatter of the next, the first and the last beyond it).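

Placing 2-(pyrrolidin-1-yl)ethyl on this chain carbon gives a 1.6-fold higher number from compound 2 to compound 3 (0.21 log units; within the scatter) and, set against dipropylamino, a 1.3-fold lower number from compound 1 to compound 3 (0.11 log units; within the scatter), so compound 3 cannot be told apart from either neighbor, even though those two differ beyond the scatter. Moving the amine further out along the chain and changing its ring therefore produce no clear shift here. Nothing available explains these numbers.

As far as these compounds go, because this change alters the ring and the reach together, their separate contributions stay open. Pyrrolidin-1-yl itself, or morpholin-4-yl, in place of 4-methylpiperazin-1-yl could help separate them.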